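The compounds below may be only part of what the source reports. "The series", "measured", "known", "first", "only" and "open" are said of these compounds alone.

Among the measured compounds shown here, compound 1, with the structure `Cc1cc(Oc2ccc(/C=N/NC(=S)Nc3ccc(Br)cc3)cc2)ccc1Cl`, is one of two compounds measured in a physicochemical assay for lipophilicity, in phosphate buffer, measured as octanol-water partition, with a stated time of 24 h; a higher number here means a more lipophilic compound, a lower number a more polar compound; there compound 1 gives 7.89. Its companion, compound 2 with the structure `Fc1ccc(Oc2ccc(/C=N/NC(=S)Nc3ccc(Br)cc3)cc2)cc1`, gives 5.82 in this assay. For the measured compounds named here, of the two numbers, compound 1 stands highest, and the only measured step, a number 2.07 log units lower from compound 1 to compound 2 (beyond the scatter), arises from a 4-fluorophenyl in place of a 4-chloro-3-methylphenyl on an oxygen on an aromatic ring.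

Compound 3, with the structure `Cc1cc(Oc2ccc(/C=N/NC(=S)Nc3ccccc3)cc2)ccc1Cl`, has not yet been measured in this assay. It differs from compound 1 as follows: hydrogen in place of bromo on an aromatic carbon. Read one bond further out, this is 4-bromophenyl to phenyl, or (4-bromophenyl)amino to anilino. Going by the values given here, no measured step concerns this place on the shared core; the step from compound 1 to compound 2 touches a different ring and therefore bears on it only as a sign that this assay can swing widely. Among the compounds with values here, with no direct precedent, the author expects a step of a number 0.79 log units lower from compound 1 to compound 3 (beyond the scatter), that is, a moderate move downward rather than upward. Compound 3 is therefore estimated at 7.1, with a range from 6.4 to 7.8.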

Compound 3, partition coefficient: 6.03
Estimate against measurement, compound 3: 1.07 log units above, outside the stated range (below it).
By their numbers in this assay, from the lowest: compounds 2 and 3 (each within the scatter of the next); then compound 1.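

In this assay, taking away one heavy atom, the bromo, and leaving hydrogen on an aromatic carbon para to a large group gives a number 1.86 log units lower from compound 1 to compound 3 (beyond the scatter), and this step is large. The earlier step, a number 2.07 log units lower from compound 1 to compound 2 (beyond the scatter), concerned the group on the oxygen, so it said nothing about this place; the new step shows that a second, different ring of the shared core also carries a large change in this read-out, and that this change can come from a single atom. No measurement at hand accounts for the size of this step.

The compounds shown leave open how a fluoro, a methoxy, an amine or a carboxylic acid would read at this place: bromo and hydrogen are the only two groups seen there so far. They also leave open whether the step from bromo to hydrogen would keep its size on a core carrying 4-fluorophenyl on the oxygen in place of 4-chloro-3-methylphenyl.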